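Aminothiazole ketones: moving from aryl ketone to carboxamide

The compounds below may be only part of what the source reports. "The series", "measured", "known", "first", "only" and "open" are said of these compounds alone.

Two compounds in this series carry a measurement so far. Compound 1 `Nc1nc(NC2CCCCC2)sc1C(=O)c1ccccc1` and compound 2 `Nc1nc(Nc2ccccc2)sc1C(=O)c1ccc(F)cc1` share the aminothiazole core and differ both at the ring nitrogen substituent and at the ketone aryl group. In a functional assay on GC-1 cells (Mus musculus) for cytotoxicity, read by MTT assay, with a stated time of 72 h (on this read-out higher numbers stand for weaker inhibition and lower numbers for stronger inhibition), compound 1 gives 9200 nM, and in this assay compound 2 gives 16000 nM. Compound 2 holds the highest of the two numbers, but the gap to compound 1 lies within the scatter, so the two stand together rather than in any order.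

Compound 3 `NC(=O)c1sc(Nc2ccccc2)nc1N` is not yet measured in this assay. It differs from compound 2 by amino in place of 4-fluorophenyl on a carbonyl carbon. For the measured compounds named here, no measured pair shows the same change, so no size can be read from the data. Given that compound 2 gives 16000 nM, the expected step is a 1.9-fold higher number from compound 2 to compound 3 (0.27 log units; within the scatter), towards a weaker read-out. Compound 3 is estimated at 30000 nM, with a range from 8000 nM to 100000 nM.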

Compound 3, half-maximal inhibitory concentration: > 60000 nM
Compound 3 was reported as a limit; the forecaster's own chance of this, stated with the estimate: 30%; middle value at least 2.0-fold (0.30 log units) away from the limit.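

Compound 3 stands at a limit in this assay, not at a number: the limit of > 60000 nM in this assay, at which 1 of the 3 values shown sits. Amino in place of 4-fluorophenyl on a carbonyl carbon gives an at least 3.7-fold higher number from compound 2 to compound 3 (0.57 log units; beyond the scatter), so this position is not indifferent in the one pair that can be read, and the change runs towards a weaker read-out. The earlier compounds shown here differed in two places and could not show this; the size of the step remains a floor only.

As far as these compounds go, how far compound 3 lies past the limit stays open, so the full size of the change cannot be read. Also open, from the compounds shown here alone, is whether the loss follows from removing the aromatic ring or from bringing in amino, which a methyl group or a benzylamine on the same carbonyl carbon could help to separate.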